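Plasma protein binding across three benzoxazolone and related acids

The source may hold more compounds than are shown below. What is called first, only, known or untested is meant among the compounds shown, and "the series" means these compounds.

Measured so far:
compound 1 `O=C(O)CCn1c(=O)oc2cc(OCc3ccccn3)c(Cl)cc21` – 92.6%
compound 2 `C[C@@H](Oc1cc2c(cc1Cl)N(CCC(=O)O)C(=O)CO2)c1ccccn1` – 92.5%
compound 3 `Cc1ccc([C@@H](C)Oc2cc3onc(CCC(=O)O)c3cc2Cl)nn1` – 92.9%

All three compounds were tested in an ADME assay on a cell-free system (plasma, Homo sapiens) for protein binding. Compound 1 gives 92.6%, compound 2 gives 92.5% and compound 3 gives 92.9%. Compound 1 stands second among the three on the unbound fraction, but its gaps to compound 2 and to compound 3 both lie within the scatter, so the three values cannot be told apart; the series is flat on this read-out.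

Compound 4 `C[C@@H](Oc1cc2oc(=O)n(CCC(=O)O)c2cc1Cl)c1cccnn1` is not yet measured. It differs from compound 1 in a single place: a group of 8 heavy atoms (6 carbon, 2 nitrogen; one six-membered aromatic ring with 2 hetero atoms) in place of a group of 7 heavy atoms (6 carbon, 1 nitrogen; one six-membered aromatic ring with 1 hetero atom), on an oxygen on an aromatic ring The group that enters carries one defined stereocentre and a second ring nitrogen.

Among the compounds with values here, no step between measured compounds is known, so there is no measured guide for this kind of change. Given that compound 2 shows 92.5% and compound 3 shows 92.9% with groups of related make-up, no step beyond the scatter is expected; compound 4 is expected to give 92.5% (range 88% to 96%), a step of a 1.0-fold higher unbound fraction from compound 1 to compound 4 (0.01 log units; within the scatter) that is expected to stay within the scatter.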

Compound 4, plasma protein binding: 68.1%
Compound 4: middle estimate off by 4.3-fold (0.63 log units) (unbound fraction), on the low side; measured number outside the range, below it.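

At the oxygen on an aromatic ring, replacing (pyridin-2-yl)methyl with the group that carries a second ring nitrogen and a defined stereocentre gives, in this assay, a 4.3-fold higher unbound fraction from compound 1 to compound 4 (0.63 log units; beyond the scatter), so this place can move the read-out. Compound 1, compound 2 and compound 3 looked flat, but they differ from one another in more than one place, so they could not reveal this sensitivity. Nothing measured here accounts for the step.

Going by these compounds, the step carries two changes at once, so it remains open whether the second ring nitrogen, the stereocentre or both produce it. A phenyl ring in the same place on the core of compound 1, with no ring nitrogen, would add a further point of comparison.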